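A few compounds are considered here, and "the series" means these few. Any claim that something is new, unique, unknown or untested is made for them only; others in the source may bear on it.

Working notes on the series.

Three compounds share the core seen in compound 1, `CN1CCCN(CCn2ccc3cc(Br)ccc32)CC1`, with a bromine on the aromatic part and a seven-membered ring carrying two nitrogens at the end of a two-carbon chain. In an assay on HEK293 cells for binding affinity to 5-hydroxytryptamine receptor 7 (Homo sapiens), read by radioligand binding, tested at 1 uM (a lower number here means less inhibition, a higher number more inhibition at the concentration tested (going by the name of the read-out)), compound 1 gives 65%. Compound 2, `CN1CCCN(CCn2ccc3cccc(Br)c32)CC1`, differs in where the bromine sits on the aromatic part, and in this assay compound 2 gives 18%. Compound 3, `Brc1ccc2ccn(CCN3CCCNCC3)c2c1`, has a hydrogen instead of a methyl on the ring amine, and in this assay compound 3 gives 77%. On these three numbers compound 3 stands highest: the gap to compound 1 lies beyond the scatter, and the gap to compound 2 lies well beyond it. No pair of these compounds differs in just one place, so no single step is isolated.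

Compound 4, `CC(C)CN1CCCN(CCn2ccc3ccc(Br)cc32)CC1`, is the next compound to be tested in this assay. It relates to compound 3 by isobutyl in place of hydrogen on an amine nitrogen in a ring. On these data alone, the change from hydrogen to methyl on this ring nitrogen is not isolated among the measured compounds, so its effect is unknown. A modest downward step is expected, and the estimate for compound 4 is 60%, with a range from 35% to 85%, corresponding to an expected step of a number 17 percentage points lower from compound 3 to compound 4 (beyond the scatter).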

Compound 4, a percentage reported as inhibition, at one concentration (the size of the read-out at that concentration, not a potency): 95%
The estimate for compound 4 lay 35 percentage points below the measured number, and the stated range ends below it.
By their numbers in this assay, from the lowest: compound 2; then compound 1; then compound 3; then compound 4.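

In this assay, for the compounds shown here, isobutyl in place of hydrogen on an amine nitrogen in a ring gives a number 18 percentage points higher from compound 3 to compound 4 (beyond the scatter), the first single change that can be read on its own. This ring nitrogen of the seven-membered ring therefore need not keep its hydrogen for inhibition to be retained at the concentration tested: a substituent with 4 heavy atoms, no ring and no hydrogen-bond donors or acceptors goes with a higher number here, and compound 4 reaches 95%. Nothing available bears on why this step goes upward, so the result stands as an observation only.

On these data alone, whether the rise depends on the branching or the size of the group remains open, since a single substituent cannot separate the two; a methyl, a straight butyl chain or a benzyl group on this nitrogen, with the rest of compound 4 unchanged, would address that. Compound 1 and compound 2 each differ from compound 4 in more than one place, so they cannot show whether the same step would hold with the bromine placed as it is in those compounds.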